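Sulfone series: difluorophenyl in place of cyanophenyl

This account rests on a few compounds, and the source may have more. Where it says the series, first, only, none or still open, it means among the compounds named here.

Measured so far:
compound 1 `COc1cccc(-c2c(S(=O)(=O)c3cc(F)cc(F)c3)cnc3cc(F)ccc23)c1` — 1.81 mL/min
compound 2 `N#Cc1cccc(S(=O)(=O)c2cnc3cc(F)ccc3c2-c2cccc(Cl)c2)c1` — 0.99 mL/min

In an ADME assay on microsomes from liver (Homo sapiens) for metabolic stability, tested at 2.5 uM (on this read-out higher numbers stand for fast clearance and lower numbers for slow clearance), compound 2 gives 0.99 mL/min, and compound 1 gives 1.81 mL/min; the two lie within the usual scatter of each other, so compound 2 stands level with compound 1 here. Compound 3 `O=S(=O)(c1cc(F)cc(F)c1)c1cnc2cc(F)ccc2c1-c1cccc(Cl)c1` is not yet measured in this assay. It differs from compound 2 by 3,5-difluorophenyl in place of 3-cyanophenyl on a sulfonyl sulfur. The expected step of a 1.4-fold higher number from compound 2 to compound 3 (0.15 log units; within the scatter) is small and upward, not beyond the scatter, because compound 1 gives 1.81 mL/min with the same 3,5-difluorophenyl on the sulfonyl sulfur. Compound 3 is estimated at 1.4 mL/min, in a range from 0.7 mL/min to 2.8 mL/min.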

Compound 3, intrinsic clearance in a liver preparation (reported as CLH), per the amount of preparation that the assay uses: 0.22 mL/min
Compound 3: the middle estimate sits 6.4-fold (0.80 log units) above what was measured, outside the stated range (below it).
By their numbers in this assay, from the lowest: compound 3; then compounds 2 and 1 (each within the scatter of the next).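

On the sulfonyl sulfur, 3,5-difluorophenyl in place of 3-cyanophenyl gives a 4.5-fold lower number from compound 2 to compound 3 (0.65 log units; beyond the scatter) in this assay, so this position can move clearance beyond the scatter. Chloro in place of methoxy on an aromatic carbon gives an 8.2-fold lower number from compound 1 to compound 3 (0.92 log units; beyond the scatter), so a second position also matters, and compound 3 carries both of these groups. Nothing at hand explains either step. From the compounds shown here alone, whether either step holds with the other group changed remains open. So does the outcome with an amine or a trifluoromethyl at these two places.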